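Bromo for methoxy on the aryl ring of compound 3

The source may hold more compounds than are shown below. What is called first, only, known or untested is meant among the compounds shown, and "the series" means these compounds.

Compound 3 `COc1ccc(OC)c(-c2nc(Cc3c[nH]c4ccccc34)no2)c1` carries two methoxy groups on its aryl ring. In a functional assay on cells (Splenocyte, Mus musculus, strain BALB/c) for inhibition, read by scintillation counting and thymidine incorporation, with stated times of 48 h and 8 h (a lower number here means a stronger inhibitor, a higher number a weaker inhibitor), compound 3 gives only a limit, > 50000 nM. Compound 1 `COc1ccccc1-c1nc(Cc2c[nH]c3ccccc23)no1` gives 16700 nM in this assay, and compound 2 `COc1cccc(-c2nc(Cc3c[nH]c4ccccc34)no2)c1` gives 18500 nM; the two numbers lie within the usual scatter of each other. Compound 3 thus sits at the limit of > 50000 nM in this assay, at which 1 of the 3 values shown sits.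

Compound 4 `COc1ccc(Br)c(-c2nc(Cc3c[nH]c4ccccc34)no2)c1` differs from compound 3 by bromo in place of methoxy on an aromatic carbon. Within the data shown here, no measured step shows bromo entering anywhere. Among the measured compounds shown here, the steps that bear on the change are an at least 2.9-fold higher number from compound 1 to compound 3 (0.47 log units; beyond the scatter) and an at least 2.7-fold higher number from compound 2 to compound 3 (0.43 log units; beyond the scatter), both describing a second methoxy entering and both weakening; compound 4 removes that second methoxy, so some recovery toward the numbers of compound 1 and compound 2 is the likeliest outcome, with the bromo itself an unknown. The expected step of an at least 2.0-fold lower number from compound 3 to compound 4 (0.30 log units; that floor lies within the scatter) is therefore a lower number, its size uncertain as compound 3 is only a limit. Compound 4 is estimated at 25000 nM, range 8000 nM to 60000 nM.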

Compound 4, half-maximal inhibitory concentration: 13300 nM
The estimate for compound 4 lay 1.9-fold (0.27 log units) above the measured number; the range from low to high includes it.
By their numbers in this assay, from the lowest: compounds 4, 1 and 2 (each within the scatter of the next). At a limit, above all of these: compound 3.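

In this assay, bromo in place of methoxy gives an at least 3.7-fold lower number from compound 3 to compound 4 (0.57 log units; beyond the scatter), so the loss seen with the second methoxy does not extend to every group on this aromatic carbon. Bromo in place of hydrogen on the same carbon gives a 1.4-fold lower number from compound 2 to compound 4 (0.14 log units; within the scatter), so a substituent here is tolerated, at least when that substituent is bromo, and the penalty so far belongs to methoxy alone. The size of the first step is only a floor, as one end of it is a limit: the limit of > 50000 nM in this assay, at which 1 of the 4 values shown sits.

From the compounds shown here alone, whether a chloro group, an amine or a carboxylic acid on this carbon would track bromo or methoxy remains open. Also open, going by these compounds, is whether bromo would hold its value without the remaining methoxy group, and these compounds give no reason for the difference between bromo and methoxy.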